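Methylpiperazine in Place of the Triazolyl Sulfide

A few compounds are considered here, and "the series" means these few. Any claim that something is new, unique, unknown or untested is made for them only; others in the source may bear on it.

Measured so far:
Compound 1, `Cn1c(-c2ccc(NC(=O)CSc3nc4ccccc4s3)cc2)nc(-c2ccccc2)c1-c1ccccc1`, gives 27% in a functional assay on MCF7 cells (Homo sapiens) for cytotoxicity, read by MTT assay, with a stated time of 24 h, tested at 6.4 ug/mL; a lower number here means a weaker effect, a higher number a stronger effect of the compound at the concentration tested.
Compound 2, `Cn1cnnc1SCC(=O)Nc1ccc(-c2nc(-c3ccccc3)c(-c3ccccc3)n2C)cc1`, gives 59.2% in this assay.

Compound 2 stands highest of the two numbers; its nearest neighbour is compound 1, and the step of a number 32.2 percentage points higher from compound 1 to compound 2 (beyond the scatter) lies beyond the scatter. The next compound, compound 3, `CN1CCN(CC(=O)Nc2ccc(-c3nc(-c4ccccc4)c(-c4ccccc4)n3C)cc2)CC1`, is not yet measured. It differs from compound 2 at one place: 4-methylpiperazin-1-yl in place of (4-methyl-4H-1,2,4-triazol-3-yl)sulfanyl on a saturated chain carbon bound to a carbonyl carbon.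

Going by the values given here, the only measured step, a number 32.2 percentage points higher from compound 1 to compound 2 (beyond the scatter), exchanged one ring on the sulfur for another and moved the read-out a long way, so the group at this position clearly matters. That step does not cover the change now made, in which the sulfur itself leaves together with its ring and a 4-methylpiperazin-1-yl enters on the saturated chain carbon bound to the carbonyl carbon. Among the compounds with values here, no measured pair shows what such an exchange does, so the direction cannot be taken from the data, and a step of either sign beyond the scatter is possible.

Compound 3 is therefore expected to give about 45% in this assay, within 15% to 75%. The step this estimate means, a number 14.2 percentage points lower from compound 2 to compound 3 (beyond the scatter), is an expectation only, carrying wide uncertainty.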

Compound 3, a percentage reported as activity, at one concentration (the size of the read-out at that concentration, not a potency): 28.6%
The estimate for compound 3 lay 16.4 percentage points above the measured number, and the stated range covers the measured number.
By their numbers in this assay, from the lowest: compounds 1 and 3 (each within the scatter of the next); then compound 2.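

Leaving the sulfur in place and changing only its ring was the earlier test; this result shows what happens when the sulfur and its ring are replaced together. In this assay, 4-methylpiperazin-1-yl in place of (4-methyl-4H-1,2,4-triazol-3-yl)sulfanyl gives a number 30.6 percentage points lower from compound 2 to compound 3 (beyond the scatter) on the saturated chain carbon bound to the carbonyl carbon, so the same count of heavy atoms at this position does not keep the read-out of compound 2. Set against the benzothiazole compound, the same group gives a number 1.6 percentage points higher from compound 1 to compound 3 (within the scatter) and a clearly different structure at this position therefore shows no separation, leaving the (4-methyl-4H-1,2,4-triazol-3-yl)sulfanyl group alone at the top among these three compounds. No accompanying measurement on these compounds bears on what lies behind these numbers.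

The three compounds do not separate the part of the sulfur from the part of the triazole ring, as both leave together; a methylene group in place of the sulfur with the triazole kept would pull them apart. From the compounds shown here alone, whether other saturated rings such as morpholine, or a simple dimethylamino group, behave like the 4-methylpiperazin-1-yl group also remains open.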